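A few compounds are considered here, and "the series" means these few. Any claim that something is new, unique, unknown or untested is made for them only; others in the source may bear on it.

Measured so far in a functional assay on NCI-H460 cells (Homo sapiens) for cytotoxicity, read by MTT assay, with a stated time of 72 h; on this read-out lower numbers stand for stronger inhibition and higher numbers for weaker inhibition:
compound 1 `CN(C)CCCNc1nc(-c2ccc(NC(=O)Nc3ccc(Cl)cc3)cc2)nc2c(Cl)c(Cl)sc12` gives 230 nM
compound 2 `CCN(CC)CCCNc1nc(-c2ccc(NC(=O)Nc3ccc(Cl)cc3)cc2)nc2c(Cl)c(Cl)sc12` gives 270 nM
compound 3 `CCN(CC)CCNc1nc(-c2ccc(NC(=O)Nc3ccc(F)cc3)cc2)nc2c(Cl)c(Cl)sc12` gives 500 nM

Compound 3 stands apart from compound 1 beyond the scatter, while its gap to compound 2 lies within it. Compound 4 `CCN(CC)CCNc1nc(-c2ccc(NC(=O)Nc3ccc(Cl)cc3)cc2)nc2c(Cl)c(Cl)sc12` is the next analogue; the change is chloro in place of fluoro on an aromatic carbon. Going by the values given here, no measured step covers this exchange of halogen. Among the compounds with values here, the only measured step, a 1.2-fold higher number from compound 1 to compound 2 (0.07 log units; within the scatter), concerns the amine end and stays within the scatter. Within the data shown here, compound 4 carries the same chloro end and shorter chain as no measured compound together; compound 2 shares only the chloro end and gives 270 nM. Expected: no step beyond the scatter, a 1.4-fold lower number from compound 3 to compound 4 (0.15 log units; within the scatter). Compound 4 is therefore estimated at 350 nM, in the range 150 nM to 800 nM.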

Compound 4, half-maximal inhibitory concentration: 320 nM
Compound 4: middle estimate off by 1.1-fold (0.04 log units), on the high side; low and high end bracket the measured number.
By their numbers in this assay, from the lowest: compounds 1, 2, 4 and 3 (each within the scatter of the next, the first and the last beyond it).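

In this assay, chloro in place of fluoro on the phenyl ring at the urea end gives a 1.6-fold lower number from compound 3 to compound 4 (0.19 log units; within the scatter), so this first measured halogen exchange at this position stays within the scatter. At the amine end, diethylamino in place of (diethylamino)methyl gives a 1.2-fold higher number from compound 2 to compound 4 (0.07 log units; within the scatter), and diethylamino in place of (dimethylamino)methyl gives a 1.4-fold higher number from compound 1 to compound 4 (0.14 log units; within the scatter), so neither step exceeds the scatter. No measurement offered here accounts for these steps.

From the compounds shown here alone, whether bromo, methoxy or an unsubstituted phenyl at this position would move the number beyond the scatter remains open. The same holds for a morpholine or a longer chain at the amine end.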